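Swapping a Halogenated Ring on the Shared Core

This account rests on a few compounds, and the source may have more. Where it says the series, first, only, none or still open, it means among the compounds named here.

Compound 1, `COc1ccccc1/C=c1/[nH]c(=O)/c(=C\c2ccccc2OC)n(C)c1=O`, gives 16200 nM in a functional assay on HL-60 cells (Homo sapiens) for cytotoxicity, read by CCK-8 assay, with a stated time of 72 h; a lower number here means a stronger inhibitor, a higher number a weaker inhibitor.
Compound 2, `C=CCn1c(=O)/c(=C\c2cccc(F)c2)[nH]c(=O)/c1=C\c1ccccc1OC`, gives 8890 nM in this assay.

Both compounds keep the same core and one ring bearing a methoxy group; they differ in the group on the nitrogen and in the second ring. Among the measured compounds shown here, of the two numbers measured so far, compound 2 has the lower one, but its gap to compound 1 lies within the usual scatter, so the two cannot be ranked against each other.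

Compound 3, `C=CCn1c(=O)/c(=C\c2cccc(Cl)c2Cl)[nH]c(=O)/c1=C\c1ccccc1OC`, has not yet been measured. It differs from compound 2 in one place: 2,3-dichlorophenyl in place of 3-fluorophenyl on a double-bonded chain carbon bound to an aromatic carbon.

For the measured compounds named here, no pair of measured compounds shows what such an exchange of one halogenated ring for another does here, so there is no measured step to lean on. The step of a 1.3-fold lower number from compound 2 to compound 3 (0.10 log units; within the scatter) is expected to be small, most likely within the scatter, with no clear direction. Compound 3 is therefore expected to give about 7000 nM, with a plausible range from 2500 nM to 20000 nM.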

Compound 3, half-maximal inhibitory concentration: 2000 nM
Estimate against measurement, compound 3: 3.5-fold (0.54 log units) above; measured number outside the range, below it.
By their numbers in this assay, from the lowest: compound 3; then compounds 2 and 1 (each within the scatter of the next).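

Exchanging 3-fluorophenyl for 2,3-dichlorophenyl on a double-bonded chain carbon bound to an aromatic carbon gives a 4.4-fold lower number from compound 2 to compound 3 (0.65 log units; beyond the scatter) in this assay and is a modest step. It is the first single change shown here, and it reveals that the number in this assay responds to which halogenated ring stands at this place, something compound 1 and compound 2 could not show, as they differ in more than one place and lie within the scatter of each other. The two rings differ in more than one respect at once, and no measurement bearing on why the number falls is available.

Still open, from the compounds shown here alone, is whether a plain phenyl or a 3-chlorophenyl ring at this place would give a number closer to that of compound 2 or to that of compound 3, which would begin to separate the kind of halogen from the rest of the change. Also open, going by these compounds, is whether an amine or a carboxylic acid on this ring would keep the lower number seen with compound 3.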